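The source may hold more compounds than are shown below. What is called first, only, known or untested is meant among the compounds shown, and "the series" means these compounds.

Measured compounds:
compound 1 `Nc1ccccc1NC(=O)/C=C/c1ccc(CSc2ccc(Cl)cc2)cc1` — 59.6%
compound 2 `Nc1ccccc1NC(=O)c1ccc(CSc2ccc(F)cc2)cc1` — 44.5%
compound 3 `COc1ccc(SCc2ccc(C(=O)Nc3ccccc3N)cc2)cc1OC` — 80.1%

All three were tested in a functional assay on A549 cells (Homo sapiens) for inhibition, read by CCK-8 assay, with a stated time of 72 h, tested at 8 uM; a higher number here means more inhibition of growth at the concentration tested, a lower number less inhibition of growth. Compound 1 stands second highest of the three numbers. Its nearest neighbour is compound 2, whose value is lower by a gap that lies beyond the usual scatter of this assay, and the furthest is compound 3, whose value is higher, again beyond the scatter. Compound 1 is thus neither the strongest nor the weakest of the three.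

The unmeasured compound 4 `CCc1ccc(SCc2ccc(/C=C/C(=O)Nc3ccccc3N)cc2)cc1` keeps the core of compound 1 and changes one group only: ethyl in place of chloro on an aromatic carbon. The group that leaves and the group that enters are both small, neither carries a hydrogen-bond donor or acceptor, and both sit para to a large group on the same six-membered aromatic ring of carbon only.

Within the data shown here, no pair of measured compounds differs by a single change, so there is no measured step to lean on. For a swap of this kind between two small groups with no donors or acceptors, the step is expected to be small, within the scatter, with no clear direction. The expected step from compound 1 to compound 4 is therefore a number 1.6 percentage points lower from compound 1 to compound 4 (within the scatter). In this assay compound 4 is estimated to give 58%, with a likely range from 43% to 72%.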

Compound 4, percent growth inhibition at one concentration: 68.6%
Compound 4: middle estimate off by 10.6 percentage points, on the low side; measured number inside the range.
By their numbers in this assay, from the lowest: compound 2; then compounds 1 and 4 (each within the scatter of the next); then compound 3.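

Compound 1 and compound 4 are the only pair shown that differs in one place, so they give the first direct look at this position on the aromatic ring, para to a large group. In this assay ethyl in place of chloro gives a number 9 percentage points higher from compound 1 to compound 4 (within the scatter) and this single step therefore leaves the two compounds indistinguishable in this read-out, with no direction that can be claimed. At this position, the two groups can stand in for each other without a difference that rises above the scatter, and nothing shown gives a reason for this result.

As far as these compounds go, whether a group of another kind at the same place, such as an amine, a carboxylic acid or a longer chain like hexyl, would move the number beyond the scatter stays open. Compound 2 and compound 3 differ from compound 1 in more than one place, so the gaps among them cannot yet be assigned to any single part of the structure, including the ring substituent studied here.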